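Swapping Fluoro for Methyl on One Aromatic Carbon

The source may report more compounds than this note shows. Statements on the series, on what has been measured and on what is new or still open speak of the compounds shown alone.

For the measured compounds named here, in a functional assay on K562 cells (Homo sapiens) for inhibition, read by trypan blue exclusion, with a stated time of 72 h (on this read-out lower numbers stand for stronger inhibition and higher numbers for weaker inhibition), compound 2 `Cn1c(=O)c(S(=O)(=O)c2ccc(F)cc2)cc2cnc(Nc3cccc4[nH]ccc34)nc21` gives 750 nM, the lower of the two numbers measured so far. In this assay, compound 1 `Cn1c(=O)c(S(=O)(=O)c2ccc(Cl)cc2)cc2cnc(Nc3cccc4[nH]ccc34)nc21` gives 5000 nM. Compound 3 `Cc1ccc(S(=O)(=O)c2cc3cnc(Nc4cccc5[nH]ccc45)nc3n(C)c2=O)cc1` keeps the shared core and differs from compound 2 at one place: methyl in place of fluoro on an aromatic carbon. This puts methyl in place of fluoro on an aromatic carbon, para to a large group, turning 4-fluorophenyl into 4-methylphenyl. Going by the values given here, one measured step bears on this place: a 6.7-fold lower number from compound 1 to compound 2 (0.82 log units; beyond the scatter), with fluoro in place of chloro, which is beyond the scatter. Among the compounds with values here, no methyl compound has been measured, so the guide is thin. Leaving fluoro is expected to raise the number, probably by less than that step. The estimated change is a 2.4-fold higher number from compound 2 to compound 3 (0.38 log units; beyond the scatter), toward weaker inhibition. Compound 3 is expected at 1800 nM, within an estimated range of 600 nM to 5500 nM.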

Compound 3, half-maximal inhibitory concentration: 5000 nM
Beside the measured number, compound 3's estimate is 2.8-fold (0.44 log units) below it, within the range that was stated.
By their numbers in this assay, from the lowest: compound 2; then compounds 1 and 3 (each within the scatter of the next).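

In this assay, fluoro is set apart from methyl as well as from chloro at this place on the ring, with methyl giving a clearly weaker result (a 6.7-fold higher number from compound 2 to compound 3 (0.82 log units; beyond the scatter)). The methyl and chloro compounds cannot be told apart (no change at the digits printed from compound 1 to compound 3 (within the scatter)), so of the three groups on this aromatic carbon, only fluoro gives the lower number. Nothing measured here explains why fluoro differs from the other two groups.

Going by these compounds, what a hydrogen, a methoxy group or a nitrile would give on this same carbon remains open. So does whether the gap between fluoro and methyl would hold if the sulfonyl link to this ring were replaced by a carbonyl.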